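Methoxy addition and chain length in sigma-1 binding

A few compounds are considered here, and "the series" means these few. Any claim that something is new, unique, unknown or untested is made for them only; others in the source may bear on it.

Going by the values given here, compound 1 `COc1cc2c(cc1OC)CN(CCCCC(=O)c1c(C)c(OC)c(OC)c(OC)c1OC)CC2` is the one compound of the four with a number rather than a limit: in an assay on membranes from brain for displacement of a labelled ligand from Sigma non-opioid intracellular receptor 1 (Cavia porcellus), read by scintillation counting, with a stated time of 120 min (a lower number here means a stronger inhibitor, a higher number a weaker inhibitor), compound 1 gives 160 nM. Compound 2 `COc1cc2c(c(OC)c1OC)CCN(CCCCC(=O)c1c(C)c(OC)c(OC)c(OC)c1OC)C2` carries the change (methoxy in place of hydrogen on an aromatic carbon), and in this assay compound 2 gives > 1000 nM, a limit of the assay. The step of an at least 6.2-fold higher number from compound 1 to compound 2 (0.79 log units; beyond the scatter) therefore rests on that limit (the limit of > 1000 nM in this assay, at which 2 of the 3 values shown sit). Compound 3 `COc1cc2c(cc1OC)CN(CCCCCC(=O)c1c(C)c(OC)c(OC)c(OC)c1OC)CC2` has a longer chain between the amine and the carbonyl; how its core differs from that of compound 1 is not broken down here. In this assay compound 3 gives > 1000 nM, again a limit. Compound 4 `COc1cc2c(c(OC)c1OC)CCN(CCCCCC(=O)c1c(C)c(OC)c(OC)c(OC)c1OC)C2` is the unmeasured member, differing from compound 3 by methoxy in place of hydrogen on an aromatic carbon, the same change as from compound 1 to compound 2. Since compound 3 already sits at the limit > 1000 nM and the same change gave an at least 6.2-fold higher number from compound 1 to compound 2 (0.79 log units; beyond the scatter), compound 4 is expected to stay beyond the limit, with the step that the limit leaves unreadable from compound 3 to compound 4 only a guess. Compound 4 is estimated at 5000 nM.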

Compound 4, inhibition constant: > 1000 nM
Compound 4 gave a limit, no number; the forecaster's own chance of this, stated with the estimate: 90%; the middle value does not contradict the limit.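

In this assay, going by these compounds alone, compound 4 gives > 1000 nM, a limit, and with compound 3 also at a limit, no step between the two can be read: the limit of > 1000 nM in this assay, at which 3 of the 4 values shown sit.

From the compounds shown here alone, how far compound 3 and compound 4 lie past that limit, and whether the methoxy change matters with the longer chain, stays open.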